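Swapping one aryl group for another at a ring nitrogen

The compounds below may be only part of what the source reports. "The series", "measured", "known", "first", "only" and "open" are said of these compounds alone.

Compound 1 `CCCn1c(=O)[nH]c2nc(-c3ccc(S(=O)(=O)N4CCN(c5ccc(F)cc5)CC4)cc3)[nH]c2c1=O` in an assay on CHO cells for displacement of a labelled ligand from adenosine receptor A2b (Homo sapiens), read by scintillation counting, with a stated time of 75 min, in the presence of a further agent that is not named here; on this read-out higher numbers stand for weaker inhibition and lower numbers for stronger inhibition: 0.644 nM
Compound 2 `CCCn1c(=O)[nH]c2nc(-c3ccc(S(=O)(=O)N4CCN(c5ccccc5C)CC4)cc3)[nH]c2c1=O` in this assay : 0.432 nM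
Compound 3 `CCCn1c(=O)[nH]c2nc(-c3ccc(S(=O)(=O)N4CCN(c5ccc(I)cc5)CC4)cc3)[nH]c2c1=O` in this assay : 0.159 nM

Compound 1 stands highest of these three numbers. Its nearest neighbour is compound 2, a 1.5-fold lower number from compound 1 to compound 2 (0.17 log units; within the scatter); the furthest is compound 3, a 4.1-fold lower number from compound 1 to compound 3 (0.61 log units; beyond the scatter). Compound 4 `CCCn1c(=O)[nH]c2nc(-c3ccc(S(=O)(=O)N4CCN(c5ccccc5Cl)CC4)cc3)[nH]c2c1=O` changes compound 1 in one place: 2-chlorophenyl in place of 4-fluorophenyl on an amine nitrogen in a ring. The step most like this one is that to compound 2, where 2-methylphenyl also replaced 4-fluorophenyl on the same ring nitrogen and the number barely moved. The larger move to compound 3 came from iodo in place of fluoro, a different kind of change. Compound 4 is therefore expected to sit close to compound 1, with a step of a 1.4-fold lower number from compound 1 to compound 4 (0.16 log units; within the scatter), and its estimated value is 0.45 nM, in the range 0.2 nM to 1 nM.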

Compound 4, inhibition constant: 0.403 nM
Compound 4: the middle estimate sits 1.1-fold (0.05 log units) above what was measured; low and high end bracket the measured number.
By their numbers in this assay, from the lowest: compound 3; then compounds 4, 2 and 1 (each within the scatter of the next).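

In this assay, 2-chlorophenyl gives a 1.6-fold lower number from compound 1 to compound 4 (0.20 log units; within the scatter), so a second group at this ring nitrogen cannot be told apart from 4-fluorophenyl. Chloro in place of methyl also leaves the number within the scatter, with a 1.1-fold lower number from compound 2 to compound 4 (0.03 log units; within the scatter), while 4-iodophenyl stays clear of the others, as a 2.5-fold higher number from compound 3 to compound 4 (0.40 log units; beyond the scatter) shows. No measurement available here explains these numbers. Going by these compounds, compound 3 and compound 4 differ in both the halogen and its place on the aromatic ring, so which of these matters stays open. On these data alone, how a pyridine ring on this nitrogen would compare also remains open.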